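A few compounds are considered here, and "the series" means these few. Any claim that something is new, unique, unknown or untested is made for them only; others in the source may bear on it.

Of the compounds shown here, three built on one shared core have been measured in an assay on isolated protein for agonist activity at Bile acid receptor (Homo sapiens), read by FRET; on this read-out higher numbers stand for larger maximal responses and lower numbers for smaller maximal responses. Compound 1 `CC(C)c1onc(-c2c(Cl)cccc2Cl)c1COc1ccc(NC(=O)c2ccc(C(=O)O)cc2)c(C(F)(F)F)n1` gives 109%. Compound 2 `CC(C)c1onc(-c2c(Cl)cccc2Cl)c1COc1ccc(NCc2ccc(C(=O)O)cc2)c(C(F)(F)F)n1` gives 97%. Compound 3 `CC(C)c1onc(-c2c(Cl)cccc2Cl)c1COc1ccc(N(C)Cc2cccc(C(=O)O)c2)c(C(F)(F)F)n1` gives 102%. Between the first two the response moved a number 12 percentage points lower from compound 1 to compound 2 (beyond the scatter). The other two steps stayed within the scatter: a number 7 percentage points lower from compound 1 to compound 3 (within the scatter) and a number 5 percentage points higher from compound 2 to compound 3 (within the scatter). Compound 3 thus stands between the other two numbers, separated from each by less than the scatter, so the three values are best read as alike.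

Compound 4 `CC(C)c1onc(-c2c(Cl)cccc2Cl)c1COc1ccc(N(C)Cc2ccc(OCCO)cc2)c(C(F)(F)F)n1` differs from compound 3 in one place: 4-(2-hydroxyethoxy)phenyl in place of 3-carboxyphenyl on a saturated chain carbon bound to a nitrogen on an aromatic ring. None of the three measured steps removes the carboxy group; each only exchanges one carboxy-bearing group for another, with or without a methyl on the nitrogen or a carbonyl in place of a saturated chain carbon, and the largest of them moved the response by a modest amount. The step to compound 4 is therefore of a kind not yet sampled, and the expected change a number 17 percentage points lower from compound 3 to compound 4 (beyond the scatter) is taken as a modest loss with wide uncertainty. Compound 4 is estimated at 85%, with an expected range from 55% to 110%.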

Compound 4, largest response reached (reported as efficacy), in percent of the reference or control that the assay uses: 87%
Compound 4: middle estimate off by 2 percentage points, on the low side; measured number inside the range.
By their numbers in this assay, from the lowest: compounds 4, 2, 3 and 1 (each within the scatter of the next, the first and the last beyond it).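

In this assay, among these compounds, the response came out a number 15 percentage points lower from compound 3 to compound 4 (beyond the scatter), and this is the first step that takes the carboxy group away, so it tests something the earlier steps could not. The loss is real but modest: compound 4 keeps a substantial maximal response at 87%, which shows that, on this saturated chain carbon bound to a nitrogen on an aromatic ring, a carboxy group is not needed for a sizeable response when 4-(2-hydroxyethoxy)phenyl takes the place of 3-carboxyphenyl. Nothing measured here explains why the response falls by this amount.

Because the step exchanges the group and also its place on the ring, the compounds shown cannot say whether the drop comes from losing the carboxy group or from the new placement. Also open, on these data alone, is how this position would respond to an amine at the end of the chain, or to a longer chain ending in a hydroxy group in place of 2-hydroxyethoxy, and since the read-out gives only the largest response reached, it leaves aside how much compound is needed to reach it.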